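Removing the N-methyl from a bridged amine at alpha3/beta4

This account rests on a few compounds, and the source may have more. Where it says the series, first, only, none or still open, it means among the compounds named here.

Compound 1 `COc1cncc(C2=CC3CC(C2)CN(C)C3)c1` carries a methyl on the amine nitrogen of its bridged ring system and a methoxy on the attached pyridine. Within the data shown here, in an in vitro functional assay on SH-SY5Y cells for agonist activity at Neuronal acetylcholine receptor; alpha3/beta4 (Homo sapiens), read by FLIPR and calcium flux (on this read-out lower numbers stand for an effect already at smaller amounts and higher numbers for an effect only at larger amounts of compound), compound 1 gives 3640 nM, which is the higher of the two numbers measured so far. Among the measured compounds shown here, the only other measured compound, compound 2 `C1=C(c2cccnc2)C[C@@H]2CNC[C@H]1C2`, gives 73 nM in this assay, a far lower number and well beyond the usual scatter; the two compounds differ in more than one place, so nothing is known about any single step between them.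

Compound 3 `COc1cncc(C2=CC3CNCC(C2)C3)c1` is the direct partner of compound 1 and differs from it in one place: hydrogen in place of methyl on an amine nitrogen in a ring. For the measured compounds named here, no measured pair shows this change on its own here, so what it does to the number is not yet known from this series.

Given that compound 1 stands at 3640 nM while a related secondary amine, compound 2, sits at 73 nM, a step from compound 1 to compound 3 of a 10-fold lower number from compound 1 to compound 3 (1.02 log units; beyond the scatter) toward a lower number is expected. Compound 3 is therefore estimated at 350 nM, with a plausible range from 70 nM to 1800 nM.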

Compound 3, half-maximal effective concentration: 105 nM
Compound 3: middle estimate off by 3.3-fold (0.52 log units), on the high side; low and high end bracket the measured number.
By their numbers in this assay, from the lowest: compounds 2 and 3 (each within the scatter of the next); then compound 1.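

In this assay, hydrogen in place of methyl on the amine nitrogen in a ring gives a 35-fold lower number from compound 1 to compound 3 (1.54 log units; beyond the scatter), so this nitrogen is a place where a change of a single carbon atom moves the number far beyond the usual scatter. Among these compounds, this is the first pair to show the change on its own: everything else in compound 1 and compound 3, including the core and the methoxy on the pyridine, is the same, so the whole step belongs to this one exchange. Why the methyl costs so much cannot be said from these results, as no measurement here bears on the cause.

On these data alone, this is still one pair, so it remains open whether the same step would appear on a pyridine without the methoxy, as in compound 2, or with another group such as a chlorine in its place. As far as these compounds go, it is also open how the number would respond to an ethyl group or a longer chain on this nitrogen, and whether it would lie nearer to that of compound 3 or that of compound 1.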